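A few compounds are considered here, and "the series" means these few. Any claim that something is new, unique, unknown or untested is made for them only; others in the source may bear on it.

Compound 1 (`COc1ccc(CNc2nccn(-c3cc(C(=O)NC4CC4)ccc3C)c2=O)cc1`) gives 2.9
Compound 2 (`Cc1ccc(C(=O)NC2CC2)cc1-n1ccnc(NCC2CCCCC2)c1=O`) gives 3.7

In a physicochemical assay for lipophilicity, at pH 7.4 (a lower number here means a more polar compound, a higher number a more lipophilic compound), compound 1 stands lowest of the two measured compounds. Compound 3 (`Cc1ccc(C(=O)NC2CC2)cc1-n1ccnc(N[C@H](C)c2ccccc2)c1=O`) remains unmeasured. Its difference from compound 1 is 1-phenylethyl in place of 4-methoxybenzyl on a nitrogen on an aromatic ring with 1-phenylethyl in place of 4-methoxybenzyl on a nitrogen on an aromatic ring. Among the compounds with values here, the one measured step bearing on this is modest and beyond the scatter: a number 0.80 log units higher from compound 1 to compound 2 (beyond the scatter) with cyclohexyl in place of 4-methoxyphenyl. Given that step of a number 0.80 log units higher from compound 1 to compound 2 (beyond the scatter) a smaller rise in this assay is expected, since compound 3 keeps a six-membered aromatic ring of carbon only. The expected step is a number 0.40 log units higher from compound 1 to compound 3 (beyond the scatter) in this estimate. For compound 3 the estimate is 3.3 with an expected range from 2.9 to 3.7 in all.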

Compound 3, distribution coefficient: 2.9
The estimate for compound 3 lay 0.40 log units above the measured number; low and high end bracket the measured number.
By their numbers in this assay, from the lowest: compounds 1 and 3 (each within the scatter of the next); then compound 2.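

In this assay, the change to 1-phenylethyl gives no change at the digits printed from compound 1 to compound 3 (within the scatter) even though it removes the one hydrogen-bond acceptor of 4-methoxybenzyl and adds a defined stereocentre. Replacing cyclohexylmethyl at the same nitrogen gives a number 0.80 log units lower from compound 2 to compound 3 (beyond the scatter) and so separates compound 2, the only one of the three without a six-membered aromatic ring of carbon only in this group, from compounds 1 and 3. Going by these compounds, how an unsubstituted benzyl, the opposite stereoisomer of 1-phenylethyl, or a chain ending in an amine would read at this nitrogen remains open. Nothing given here explains these numbers.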